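The source may hold more compounds than are shown below. What is called first, only, known or untested is meant among the compounds shown, and "the series" means these compounds.

Measured in an ADME assay on C8166 cells (Homo sapiens) for cytotoxicity, read by MTT assay; on this read-out higher numbers stand for lower toxicity in this test and lower numbers for higher toxicity in this test:
- compound 1 `CCCCCn1cc(C(=O)O)c(=O)c2c(O)c(Cc3cccc(Cl)c3F)ccc21`: 39900 nM
- compound 2 `CC(C)n1cc(C(=O)O)c(=O)c2c(O)c(Cc3cccc(Cl)c3F)ccc21`: 26500 nM
- compound 3 `CC(C)(C)n1cc(C(=O)O)c(=O)c2c(O)c(Cc3cccc(Cl)c3F)ccc21`: 400000 nM

Compound 1 belongs to the lower pair of these numbers. Its nearest step is a 1.5-fold lower number from compound 1 to compound 2 (0.18 log units; within the scatter), and its furthest is a 10-fold higher number from compound 1 to compound 3 (1.00 log units; beyond the scatter).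

Compound 4 `O=C(O)c1cn(C2CC2)c2ccc(Cc3cccc(Cl)c3F)c(O)c2c1=O` has cyclopropyl in place of pentyl on an aromatic nitrogen. Three measured steps change this same group. Besides those two, there is a 15-fold higher number from compound 2 to compound 3 (1.18 log units; beyond the scatter), so only tert-butyl stands apart.

Cyclopropyl is not tert-butyl, so the step to compound 2 is taken as the closer guide, and no step beyond the scatter is expected in this assay. The expected change is a 1.1-fold lower number from compound 1 to compound 4 (0.06 log units; within the scatter). Compound 4 is estimated at 35000 nM, with an expected range of 12000 nM to 130000 nM.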

Compound 4, half-maximal cytotoxic concentration: 39100 nM
For compound 4 the middle estimate is 1.1-fold (0.05 log units) below the measured one; the measured number falls inside the stated range.
By their numbers in this assay, from the lowest: compounds 2, 4 and 1 (each within the scatter of the next); then compound 3.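

In this assay, a ring on the aromatic nitrogen proves no different from an open chain: cyclopropyl matches pentyl (a 1.0-fold lower number from compound 1 to compound 4 (0.01 log units; within the scatter)) and isopropyl (a 1.5-fold higher number from compound 2 to compound 4 (0.17 log units; within the scatter)). The separation of tert-butyl is confirmed against this ring as well (a 10-fold lower number from compound 3 to compound 4 (1.01 log units; beyond the scatter)), leaving compound 3 alone among the four compounds.

On these data alone, it remains open whether cyclohexyl or a chain ending in an amine on this nitrogen would group with compound 3 or with the other three. Nothing available explains why compound 3 stands apart.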